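Removing the Dimethylcarbamoyl Group from Compound 3

The compounds below may be only part of what the source reports. "The series", "measured", "known", "first", "only" and "open" are said of these compounds alone.

Compound 1, `Cc1c(OC[C@@H](C)COc2ccc(F)c(C(=O)O)c2)ccc(C(=O)CC(C)(C)C)c1O`: 1180 nM
Compound 2, `Cc1cc(OC[C@H](C)COc2ccc(C(=O)CC(C)(C)C)c(O)c2C)ccc1C(=O)O`: 1350 nM
Compound 3, `COc1ccc(C(=O)N(C)C)cc1OC[C@H](C)COc1ccc(C(=O)CC(C)(C)C)c(O)c1C`: "not active" (no number reported)

In an assay for positive allosteric modulation of metabotropic glutamate receptor 3 (Rattus norvegicus) (on this read-out higher numbers stand for an effect only at larger amounts of compound and lower numbers for an effect already at smaller amounts), compound 1 gives 1180 nM and compound 2 gives 1350 nM; the step of a 1.1-fold higher number from compound 1 to compound 2 (0.06 log units; within the scatter) lies within the scatter. Compound 3 stands apart from these two: in this assay compound 3 gives "not active" (no number reported), and no number exists for it. Compound 4, `COc1ccccc1OC[C@H](C)COc1ccc(C(=O)CC(C)(C)C)c(O)c1C`, differs from compound 3 by hydrogen in place of dimethylcarbamoyl on an aromatic carbon. Among the measured compounds shown here, no measured step touches this part of the molecule, and the only measured step, a 1.1-fold higher number from compound 1 to compound 2 (0.06 log units; within the scatter), concerns the other aryl ring, so it offers no guide to direction or size here. Compounds 1 and 2 differ from compound 4 in more than one place and serve only as a loose anchor. Compound 4 is therefore estimated at 4000 nM, within a range from 800 nM to 20000 nM.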

Compound 4, half-maximal effective concentration: "not active" (no number reported)
No number was reported for compound 4, so the estimate cannot be set against anything.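

In this assay compound 3 gives "not active" (no number reported) and compound 4 gives "not active" (no number reported) so no step can be read between them, and no other data shown bear on this result. The compounds shown leave open whether the dimethylcarbamoyl group matters to this read-out at all.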